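A few compounds are considered here, and "the series" means these few. Any claim that something is new, unique, unknown or untested is made for them only; others in the source may bear on it.

Measured in a functional assay on MDA-MB-231 cells (Homo sapiens) for inhibition, read by MTT assay, with a stated time of 48 h; a higher number here means a weaker inhibitor, a lower number a stronger inhibitor:
Compound 1 `Cn1c(/C=C2\SC(=O)N(CC(=O)Nc3cc(C(C)(C)C)on3)C2=O)nc2ccccc21`: 33800 nM
Compound 2 `CC(C)n1c(/C=C2\SC(=O)N(CC(=O)N3CCCC3)C2=O)nc2ccccc21`: > 50000 nM, a limit
Compound 3 `CC(C)n1c(/C=C2\SC(=O)N(CC(=O)N3CCCCC3)C2=O)nc2ccccc21`: > 50000 nM, a limit

Compound 3 has no number, only a limit, reading > 50000 nM. Among the compounds with values here, the one further value of this kind belongs to compound 2, so only compound 1 has a number.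

Compound 4 `CC(C)n1c(/C=C2\SC(=O)N(CC(=O)Nc3cc(C(C)(C)C)on3)C2=O)nc2ccccc21` carries (5-(tert-butyl)-1,2-oxazol-3-yl)amino in place of piperidin-1-yl on a carbonyl carbon. Within the data shown here, the only measured step that exchanges a group on this carbonyl carbon is a step that the two limits leave unreadable from compound 2 to compound 3, and it offers no size to carry over. The nearest guide is compound 1, which also carries the (5-(tert-butyl)-1,2-oxazol-3-yl)amino group and gives 33800 nM. On that basis, a move toward stronger inhibition in this assay is expected, though a modest one, and the assay may again report only a limit. The estimated change is an at least 1.6-fold lower number from compound 3 to compound 4 (0.22 log units; that floor lies within the scatter). For compound 4 the expected value is 30000 nM, with an estimated range from 12000 nM to 50000 nM.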

Compound 4, half-maximal inhibitory concentration: > 50000 nM
Compound 4: no number, only a limit; the forecaster's own chance of this, stated with the estimate: 30%; at least 1.6-fold (0.22 log units) between middle value and limit.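

In this assay compound 4 also stays at a limit, so with isopropyl on the aromatic nitrogen, (5-(tert-butyl)-1,2-oxazol-3-yl)amino on this carbonyl carbon gives no number, just as piperidin-1-yl and pyrrolidin-1-yl gave none; the steps to compound 4 from compound 2 and compound 3 cannot be read. The one readable step, isopropyl in place of methyl on an aromatic nitrogen, is an at least 1.4-fold higher number from compound 1 to compound 4 (0.17 log units; that floor lies within the scatter), so the exchange is not shown to matter beyond the scatter. Almost all the readings rest on a single limit: the limit of > 50000 nM in this assay, at which 3 of the 4 values shown sit.

From the compounds shown here alone, it remains open whether a morpholin-4-yl or a dimethylamino group on this carbonyl carbon would give a number in this assay. Also open, going by these compounds, is how an ethyl group on the aromatic nitrogen would read.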